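A few compounds are considered here, and "the series" means these few. Any claim that something is new, unique, unknown or untested is made for them only; others in the source may bear on it.

Among the measured compounds shown here, compound 2, whose structure is `COc1cnc(-c2ccccn2)nc1NCc1ccccc1F`, is the only compound in this set with an actual number: in a functional assay on RAW264.7 cells (Mus musculus), with a stated time of 3 days (on this read-out higher numbers stand for weaker inhibition and lower numbers for stronger inhibition), compound 2 gives 130 nM. Compound 1, with structure `COc1cnc(-c2ccccn2)nc1NCCCC(=O)O`, differs from it at one place, and in this assay compound 1 reaches only the limit of > 10000 nM, so no number is known for it. For the measured compounds named here, the single measured step, an at least 76-fold lower number from compound 1 to compound 2 (1.88 log units; beyond the scatter), therefore rests on a limit on one side the limit of > 10000 nM in this assay, at which 1 of the 2 values shown sits, and exchanges a whole group for another.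

Compound 3, with structure `COc1cnc(-c2ccccn2)nc1NCc1ccccc1Cl`, keeps everything of compound 2 except one atom: chloro in place of fluoro on an aromatic carbon. The measured step from compound 1 to compound 2 concerns a different kind of change at the same position and gives no direct guide to swapping one halogen for another. With nothing in the data pointing either way, the step from compound 2 to compound 3 is expected to fall within the usual scatter, and the estimated step is a 1.1-fold lower number from compound 2 to compound 3 (0.03 log units; within the scatter). Compound 3 is accordingly expected to give about 120 nM in this assay, most likely between 45 nM and 320 nM.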

Compound 3, half-maximal inhibitory concentration: 520 nM
Beside the measured number, compound 3's estimate is 4.3-fold (0.64 log units) below it; measured number outside the range, above it.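

In this assay, chloro in place of fluoro on the aromatic carbon gives a 4.0-fold higher number from compound 2 to compound 3 (0.60 log units; beyond the scatter), so the exchange of one halogen for another is not neutral at this position, and compound 2, with fluoro, inhibits more strongly than compound 3, with chloro. The 2-chlorophenyl group still stands far from the 2-carboxyethyl group, with an at least 19-fold lower number from compound 1 to compound 3 (1.28 log units; beyond the scatter), which shows that the large gap seen with the 2-fluorophenyl group does not depend on fluoro alone. Compound 1 stands at a limit, so this step, like the earlier one, gives only a lower bound on the size of the change: the limit of > 10000 nM in this assay, at which 1 of the 3 values shown sits.

From the compounds shown here alone, with only two halogens compared, it remains open how a plain phenyl, a bromo or a methyl group on the same carbon would compare with fluoro and chloro. Going by these compounds, it is also open whether the gap to compound 1 follows the aromatic ring or the chain end, which an unsubstituted butyl chain or a chain ending in an amine could help separate.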